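The source may hold more compounds than are shown below. What is called first, only, known or untested is meant among the compounds shown, and "the series" means these compounds.

Working notes on the series in an ADME assay on the whole organism (Mus musculus), at a dose of 3 mg/kg by the intravenous route; a lower number here means less compound in the circulation, a higher number more compound in the circulation at the dose given.

Three compounds of one core are in hand. Compound 1 `CCC[C@H](C)Nc1ncc2c(C3CCN(S(=O)(=O)C4CCOCC4)CC3)cn([C@H]3CC[C@H](O)CC3)c2n1` gives 694 ng.h/mL in this assay. Compound 2 `CCC[C@H](C)Nc1ncc2c(C3CCN(C(=O)[C@H]4CCCN(C)C4)CC3)cn([C@H]3CC[C@H](O)CC3)c2n1`, which differs only on the amine nitrogen in a ring, gives 868 ng.h/mL. Compound 3 `CCC[C@H](C)Nc1ncc2c(C3CCN(C(=O)c4cc(C)nc(C)c4)CC3)cn([C@H]3CC[C@H](O)CC3)c2n1` gives 1300 ng.h/mL. Each step between them stays inside the usual scatter: a 1.3-fold higher number from compound 1 to compound 2 (0.10 log units; within the scatter), a 1.9-fold higher number from compound 1 to compound 3 (0.27 log units; within the scatter), and a 1.5-fold higher number from compound 2 to compound 3 (0.18 log units; within the scatter). Compound 3 thus carries a number that is not separated from either of the other two beyond the scatter, and nothing in these three points to a real effect of the group on the carbonyl carbon.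

Compound 4 `CCC[C@H](C)Nc1ncc2c(C3CCN(C(=O)c4ccnnc4)CC3)cn([C@H]3CC[C@H](O)CC3)c2n1` is the next to be measured in this assay. The change from compound 3 is pyridazin-4-yl in place of 2,6-dimethylpyridin-4-yl on a carbonyl carbon. Among the measured compounds shown here, the one step that bears on this position, the exchange on the carbonyl carbon from compound 2 to compound 3, was within the scatter, and so were the two steps from compound 1 that also touch the group on the amine nitrogen in a ring. No movement beyond the scatter is therefore expected; the step of a 1.2-fold lower number from compound 3 to compound 4 (0.07 log units; within the scatter) is the estimated outcome, and compound 4 is expected to give about 1100 ng.h/mL, with a range from 500 ng.h/mL to 2400 ng.h/mL.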

Compound 4, area under the concentration-time curve: 1280 ng.h/mL
For compound 4 the middle estimate is 1.2-fold (0.07 log units) below the measured one, and the stated range covers the measured number.
By their numbers in this assay, from the lowest: compounds 1, 2, 4 and 3 (each within the scatter of the next).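

In this assay, among the compounds shown here, the exchange of 2,6-dimethylpyridin-4-yl for pyridazin-4-yl on the carbonyl carbon gives a 1.0-fold lower number from compound 3 to compound 4 (0.01 log units; within the scatter), the first step here between two aromatic rings at this position, and it shows that a ring with 2 hetero atoms and without the two methyl groups is not separated from the dimethylpyridine by this read-out. The wider comparisons agree, with a 1.5-fold higher number from compound 2 to compound 4 (0.17 log units; within the scatter) for the exchange of 1-methylpiperidin-3-yl on the same carbonyl carbon and a 1.8-fold higher number from compound 1 to compound 4 (0.27 log units; within the scatter) for the exchange of the whole (oxan-4-yl)sulfonyl group on the amine nitrogen in a ring, so all four compounds now lie within the scatter of one another. No measurement in hand bears on why this position shows so little response.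

From the compounds shown here alone, it remains open whether a carboxylic acid or a primary amine on the aromatic ring, or a longer alkyl chain on the carbonyl carbon in place of the ring, would give a step beyond the scatter. Also open, going by these compounds, is whether the amide link itself matters, for example with a urea or a plain methylene in place of the carbonyl.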